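Cyclohexyloxy in place of 4-fluorophenyl on the acylguanidine core

The compounds below may be only part of what the source reports. "The series", "measured", "known", "first", "only" and "open" are said of these compounds alone.

Measured compounds:
compound 1, `Cc1c(C(=O)N=C(N)N)cc(S(C)(=O)=O)c(Cl)c1Cl`, 29 nM
compound 2, `Cc1cc(-c2ccc(F)cc2)c(S(C)(=O)=O)cc1C(=O)N=C(N)N`, 36 nM
compound 3, `CCc1cc(OC)c(S(C)(=O)=O)cc1C(=O)N=C(N)N`, 30 nM

In a functional assay for inhibition of sodium/hydrogen exchanger (Oryctolagus cuniculus) (on this read-out lower numbers stand for stronger inhibition and higher numbers for weaker inhibition), compound 1 gives 29 nM. Compound 2 gives 36 nM, and compound 3 gives 30 nM. Compound 2 has the highest of the three numbers, but both neighbours lie within the scatter of it: the gap to compound 3 and the gap to compound 1 are each too small to be read as a difference. The three compounds are therefore best described as indistinguishable in this assay.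

The next compound, compound 4, `Cc1cc(OC2CCCCC2)c(S(C)(=O)=O)cc1C(=O)N=C(N)N`, is derived from compound 2 by a single change, (cyclohexyloxy in place of 4-fluorophenyl on an aromatic carbon). Within the data shown here, no measured pair shows this kind of exchange, so there is no step on record to lean on. Among the measured compounds shown here, what the numbers do show is that three rather different substitution patterns around the shared core, including the one in compound 2, all fall in the same narrow band. On that basis the exchange is expected to produce no step beyond the scatter: compound 4 is estimated at 35 nM, with a plausible range from 10 nM to 120 nM, which means an expected step of a 1.0-fold lower number from compound 2 to compound 4 (0.01 log units; within the scatter).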

Compound 4, half-maximal inhibitory concentration: 37 nM
The estimate for compound 4 lay 1.1-fold (0.02 log units) below the measured number, within the range that was stated.
By their numbers in this assay, from the lowest: compounds 1, 3, 2 and 4 (each within the scatter of the next).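

In this assay, among these compounds, putting cyclohexyloxy in place of 4-fluorophenyl on the aromatic carbon ortho to a methylsulfonyl group gives a 1.0-fold higher number from compound 2 to compound 4 (0.01 log units; within the scatter), the first step on record at this position, and it cannot be read as a difference. Both groups hold 7 heavy atoms, so this pair shows that an aromatic ring carrying fluorine and a non-aromatic ring carrying a hydrogen-bond acceptor can stand at this position with no readable difference in the number. Nothing shown here accounts for why the two groups read alike.

Going by these compounds, it remains open whether this tolerance extends to groups of a different kind at the same position, such as an amine or a carboxylic acid, since the two groups compared here are both six-membered carbon rings of equal heavy-atom count. On these data alone, it is also open whether a longer chain in place of the methyl group would leave the number equally undisturbed, and whether the exchange seen here would read the same on a core carrying other substituents.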